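Working notes: 3-chlorophenyl to 4-hydroxyphenyl on an oxygen

This account rests on a few compounds, and the source may have more. Where it says the series, first, only, none or still open, it means among the compounds named here.

Measured so far in a functional assay on MCF7 cells (Homo sapiens) for antiproliferative activity, read by MTT assay, with a stated time of 72 h; a lower number here means a stronger inhibitor, a higher number a weaker inhibitor:
compound 1 `O=S(=O)(Oc1ccccc1Cl)C1CC2OC1C(c1ccc(/C=C/c3cc(O)cc(O)c3)cc1)=C2c1ccc(O)cc1` gives 40400 nM
compound 2 `Cc1ccccc1OS(=O)(=O)C1CC2OC1C(c1ccc(/C=C/c3cc(O)cc(O)c3)cc1)=C2c1ccc(O)cc1` gives 55800 nM
compound 3 `O=S(=O)(Oc1cccc(Cl)c1)C1CC2OC1C(c1ccc(/C=C/c3cc(O)cc(O)c3)cc1)=C2c1ccc(O)cc1` gives 12900 nM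

Compound 3 has the lowest number of the three. The step of a 3.1-fold lower number from compound 1 to compound 3 (0.50 log units; beyond the scatter) and the step of a 4.3-fold lower number from compound 2 to compound 3 (0.64 log units; beyond the scatter) are both modest and beyond the scatter. The step of a 1.4-fold higher number from compound 1 to compound 2 (0.14 log units; within the scatter) stays within the scatter, so these two compounds are not separated.

Compound 4 `O=S(=O)(Oc1ccc(O)cc1)C1CC2OC1C(c1ccc(/C=C/c3cc(O)cc(O)c3)cc1)=C2c1ccc(O)cc1` is still to be measured in this assay. It has 4-hydroxyphenyl in place of 3-chlorophenyl on an oxygen. Among the measured compounds shown here, no measured compound carries 4-hydroxyphenyl, so this exchange has no direct precedent. The closest evidence comes from the other changes of the group on this oxygen. These changes show that the number can shift modestly, and the group that leaves here belongs to the lowest value. With compound 1 at 40400 nM and compound 2 at 55800 nM as the only other reference points, a modest move toward a higher number is expected, of about the size of those two steps. The expected step is a 2.3-fold higher number from compound 3 to compound 4 (0.37 log units; beyond the scatter) and this estimate is uncertain. Compound 4 is estimated at 30000 nM (expected range 11000 nM to 75000 nM).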

Compound 4, half-maximal inhibitory concentration: 14100 nM
Compound 4: middle estimate off by 2.1-fold (0.33 log units), on the high side, within the range that was stated.
By their numbers in this assay, from the lowest: compounds 3 and 4 (each within the scatter of the next); then compounds 1 and 2 (each within the scatter of the next).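

In this assay, a 1.1-fold higher number from compound 3 to compound 4 (0.04 log units; within the scatter), so 4-hydroxyphenyl and 3-chlorophenyl on this oxygen are not separated, even though the exchange replaces the chlorine with an oxygen and adds a hydrogen-bond donor and acceptor to the group; the low end of this small set is therefore not tied to 3-chlorophenyl. Compound 4 also stands clear of the other two, with a 4.0-fold lower number from compound 2 to compound 4 (0.60 log units; beyond the scatter) and a 2.9-fold lower number from compound 1 to compound 4 (0.46 log units; beyond the scatter), which divides the four compounds into two pairs: 3-chlorophenyl with 4-hydroxyphenyl, and 2-chlorophenyl with 2-methylphenyl. No measurement at hand accounts for this grouping.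

The compounds shown do not separate the identity of the substituent from its place on the ring, and 3-hydroxyphenyl, 4-chlorophenyl and 2-hydroxyphenyl would be needed to do so. Also open, on these data alone, is where an unsubstituted phenyl, a 4-aminophenyl or a 4-carboxyphenyl on this oxygen would fall relative to the two pairs.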